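Amine-bearing side chains on the shared core

A few compounds are considered here, and "the series" means these few. Any claim that something is new, unique, unknown or untested is made for them only; others in the source may bear on it.

Measured so far:
- compound 1, `COc1cc(OC)c2c(=O)cc(-c3ccc(OCCBr)cc3)oc2c1`, in a functional assay (Homo sapiens) for antiproliferative activity, read by resazurin assay, with a stated time of 48 h, tested at 20 uM (a lower number here means a weaker effect, a higher number a stronger effect of the compound at the concentration tested), compound 1 gives 20%
- compound 2, `COc1cc(OC)c2c(=O)cc(-c3ccc(OCCF)cc3)oc2c1`, in this assay compound 2 gives 21%
- compound 3, `COc1cc(OC)c2c(=O)cc(-c3ccc(OC4CCN(C)CC4)cc3)oc2c1`, in this assay compound 3 is reported as "not determined" (no result reported)

Where compound 3 stands: no value has been obtained for compound 3 in this assay, so it cannot be placed against compound 1 or compound 2 on the numbers shown.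

The step to compound 4, `COc1cc(OC)c2c(=O)cc(-c3ccc(OCCCN(C)C)cc3)oc2c1`, changes the side chain on the oxygen on the aromatic ring:

3-(dimethylamino)propyl in place of 1-methylpiperidin-4-yl on an oxygen on an aromatic ring

Among the compounds with values here, only one measured step exists, a number 1 percentage points higher from compound 1 to compound 2 (within the scatter), and it concerns a different change, a halogen swap on the chain. Within the data shown here, it tells nothing direct about exchanging 1-methylpiperidin-4-yl for 3-(dimethylamino)propyl, and no step is available that touches either of those groups. The only anchor is that both halogen-bearing compounds sit in the same range in this assay, and compound 3 itself carries no number that the change could be measured from.

For compound 4 the estimate therefore rests on the range seen for compound 1 and compound 2 alone, with a wide band: compound 4 is expected to give about 22% in this assay, between 5% and 45%.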

Compound 4, a percentage reported as inhibition, at one concentration (the size of the read-out at that concentration, not a potency): 86%
Compound 4: the middle estimate sits 64 percentage points below what was measured; measured number outside the range, above it.
By their numbers in this assay, from the lowest: compounds 1 and 2 (each within the scatter of the next); then compound 4.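

In this assay, (dimethylamino)methyl in place of a halogen on the saturated chain carbon, two bonds along the chain from an oxygen on an aromatic ring, gives a number 65 percentage points higher from compound 2 to compound 4 (beyond the scatter) and a number 66 percentage points higher from compound 1 to compound 4 (beyond the scatter). Within the data shown here, the only earlier step at this carbon, fluoro in place of bromo, stayed within the scatter at a number 1 percentage points higher from compound 1 to compound 2 (within the scatter), so the two halogens gave no sign that the read-out could change so strongly with the group placed here. Nothing measured on these compounds accounts for the size of the new steps.

Compound 3 has no result, so the exchange of 1-methylpiperidin-4-yl for 3-(dimethylamino)propyl cannot be read, and the compounds shown do not say whether the ring-bearing amine would behave like the open chain. Also open, as far as these compounds go, is whether the gain belongs to the dimethylamino group specifically or would persist with a morpholine, a pyrrolidine, a primary amine or a shorter or longer chain carrying the same amine, and, as each figure comes from a single concentration, how the compounds compare in potency.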